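Methyl for methoxy on the fused ring of compound 3

The compounds below may be only part of what the source reports. "The series", "measured", "known", "first", "only" and "open" are said of these compounds alone.

Of the compounds shown here, three built on one shared core have been measured in a physicochemical assay for lipophilicity; on this read-out higher numbers stand for higher lipophilicity and lower numbers for lower lipophilicity. Compound 1 `COc1ccc2[nH]c(-c3ccccc3)c(C3=C(Br)C(=O)NC3=O)c2c1` gives 2.48, compound 2 `CCCCCCc1cccc2c(C3=C(Br)C(=O)NC3=O)c(-c3ccc(OC)cc3)[nH]c12` gives 4.27, and compound 3 `COc1cccc(-c2[nH]c3ccc(OC)cc3c2C2=C(Br)C(=O)NC2=O)c1` gives 2.79. Compound 3 stands second highest of the three: its nearest neighbour is compound 1, and the step of a number 0.31 log units higher from compound 1 to compound 3 (beyond the scatter) arose from methoxy in place of hydrogen on an aromatic carbon; compound 2 lies far higher, but no single change separates it from compound 3, so its value is only a remote reference.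

Compound 4 `COc1cccc(-c2[nH]c3ccc(C)cc3c2C2=C(Br)C(=O)NC2=O)c1` is not yet measured in this assay. It differs from compound 3 in one place: methyl in place of methoxy on an aromatic carbon, on an aromatic carbon of a six-membered aromatic ring of carbon only, part of a fused or bridged system of two rings. Within the data shown here, none of the measured steps exchanges methoxy for methyl; the only single-change step in the set, from compound 1 to compound 3, concerns methoxy entering for hydrogen and was modest in size. Taking a methyl as the lighter and less oxygen-bearing group, compound 4 is expected to sit a little higher than compound 3, a step of about a number 0.41 log units higher from compound 3 to compound 4 (beyond the scatter) in this assay. Compound 4 is therefore estimated at 3.2, with a range from 2.8 to 3.6.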

Compound 4, partition coefficient: 3.12
For compound 4 the middle estimate is 0.08 log units above the measured one; the range from low to high includes it.
By their numbers in this assay, from the lowest: compound 1; then compound 3; then compound 4; then compound 2.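

In this assay, among these compounds, methyl in place of methoxy on this aromatic carbon, meta to a fused ring and para to a fused ring, gives a number 0.33 log units higher from compound 3 to compound 4 (beyond the scatter) and so provides the first reading of a change at this position. The earlier step of a number 0.31 log units higher from compound 1 to compound 3 (beyond the scatter) came from methoxy entering for hydrogen at a different place, so a methoxy entering in one comparison and a methoxy leaving for methyl in the other both go with a higher number, and these two steps give methoxy no single direction across the compounds. Nothing in the data shown explains the size or direction of the new step.

The comparison also leaves open how hydrogen at this position would compare with methoxy and methyl, so the separate contribution of each group on this ring cannot be read. Whether an ethyl group or a chlorine here would extend the rise, and whether an amine or a carboxylic acid would reverse it, remains an open question.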